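A few compounds are considered here, and "the series" means these few. Any claim that something is new, unique, unknown or untested is made for them only; others in the source may bear on it.

In an ADME assay on the whole organism with Oryza sativa as the target, tested at 0.1 uM (on this read-out lower numbers stand for a stronger effect and higher numbers for a weaker effect at the one concentration tested), compound 3 `CC(C)c1ccccc1NC(=O)N[C@@H](C)c1ccccc1` gives 99%. Compound 1 `CCc1ccc(NC(=O)N[C@@H](C)c2ccccc2)cc1` gives 99%, level with compound 3 at the digits shown, and compound 2 `CC(C)c1ccccc1NC(=O)N[C@H](C)c1ccccc1` gives 103%. Going by the values given here, the only step measured so far, a number 4 percentage points lower from compound 2 to compound 3 (within the scatter), rests on the fact that compounds 2 and 3 differ only in the configuration as drawn and stays within the scatter, so all three numbers sit close to one another near full activity.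

Compound 4 `COc1ccccc1NC(=O)N[C@@H](C)c1ccccc1` differs from compound 3 by methoxy in place of isopropyl on an aromatic carbon. Among the compounds with values here, no measured step touches this change: the one step known swaps only a configuration, not a group on the ring, so it says nothing about exchanging isopropyl for methoxy. With every measured compound giving near-identical high numbers, and no step beyond the scatter anywhere, the plain expectation is a step of a number 1 percentage points higher from compound 3 to compound 4 (within the scatter), that is none beyond the scatter. Compound 4 is therefore estimated at 100%, with a range from 90% to 110%.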

Compound 4, a percentage reported as activity, at one concentration (the size of the read-out at that concentration, not a potency): 98%
Beside the measured number, compound 4's estimate is 2 percentage points above it; the range from low to high includes it.
By their numbers in this assay, from the lowest: compounds 4, 1, 3 and 2 (each within the scatter of the next).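

Methoxy in place of isopropyl on an aromatic carbon, ortho to a large group, gives in this assay a step of a number 1 percentage points lower from compound 3 to compound 4 (within the scatter), the first measured step that changes a group on the ring and not a configuration. At this position, a group of carbon only and no hydrogen-bond acceptor can thus give way to one with an oxygen and a hydrogen-bond acceptor, without a step beyond the scatter. Nothing known so far offers a reason for this result.

On these data alone, what an amine or a carboxylic acid on this aromatic carbon would give stays open. So does the question of whether any change to the shared core can move the number in this assay beyond the scatter.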